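Replacing isobutyl with 4-methoxyphenoxy: expected solubility of compound 4

The source may hold more compounds than are shown below. What is called first, only, known or untested is meant among the compounds shown, and "the series" means these compounds.

Measured so far in a physicochemical assay for solubility, with a stated time of 18 h, at pH 7.4; a lower number here means a less soluble compound, a higher number a more soluble compound:
compound 1, `CC(C)Cc1ccc2c(NCCCNCc3ccco3)ccnc2c1`, gives 4200 nM;
compound 2, `COc1cccc(Oc2ccc3c(NCCCNCc4cc(F)ccc4OC)ccnc3c2)c1`, gives 14500 nM;
compound 3, `COc1ccc(F)cc1CNCCCNc1ccnc2cc(CC(C)C)ccc12`, gives 4200 nM.

Compound 1 sits level with compound 3, the two together the lowest of the three numbers, and compound 2 is the furthest from it. Two single-point moves connect these: no change at the digits printed from compound 1 to compound 3 (within the scatter), and a 3.5-fold lower number from compound 2 to compound 3 (0.54 log units; beyond the scatter).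

Compound 4, `COc1ccc(Oc2ccc3c(NCCCNCc4ccco4)ccnc3c2)cc1`, differs from compound 1 in one place: 4-methoxyphenoxy in place of isobutyl on an aromatic carbon. The step that bears on this is the reverse of the one in which a 3.5-fold lower number from compound 2 to compound 3 (0.54 log units; beyond the scatter), so a rise of about that size is expected in this assay. Accordingly, for compound 4 the expected step is a 3.3-fold higher number from compound 1 to compound 4 (0.52 log units; beyond the scatter), with an estimated 14000 nM, in the range 6000 nM to 32000 nM.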

Compound 4, solubility: 14500 nM
For compound 4 the middle estimate is 1.0-fold (0.02 log units) below the measured one, and the stated range covers the measured number.
By their numbers in this assay, from the lowest: compounds 1 and 3 (each within the scatter of the next); then compounds 2 and 4 (each within the scatter of the next).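

In this assay, the change gives a 3.5-fold higher number from compound 1 to compound 4 (0.54 log units; beyond the scatter), which mirrors the earlier step at this position, a 3.5-fold lower number from compound 2 to compound 3 (0.54 log units; beyond the scatter). The link between a methoxyphenoxy group here and the higher number therefore holds with furan-2-yl as well as 5-fluoro-2-methoxyphenyl at the end of the chain, and with 4-methoxyphenoxy as well as 3-methoxyphenoxy. Nothing available explains this difference.

Still open, going by these compounds, is whether the methoxy group matters at all, or whether the ring alone is enough. Plain phenoxy at this position would address that, while a morpholine would show how a ring containing an amine compares.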